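This account rests on a few compounds, and the source may have more. Where it says the series, first, only, none or still open, it means among the compounds named here.

Measured compounds:
- compound 1 `CCNC(c1ccc(/C=C/C#N)cc1)c1ccnc(Nc2ccc(C#N)cc2)n1`: 37300 nM
- compound 2 `N#C/C=C/c1ccc(C(NO)c2ccnc(Nc3ccc(C#N)cc3)n2)cc1`: 161000 nM
- compound 3 `CC(C)NC(c1ccc(/C=C/C#N)cc1)c1ccnc(Nc2ccc(C#N)cc2)n1`: 32300 nM

All three were read in an ADME assay on MT4 cells (Homo sapiens) for cytotoxicity, read by MTT assay, with a stated time of 5 days; on this read-out higher numbers stand for lower toxicity in this test and lower numbers for higher toxicity in this test. On these numbers compound 3 stands lowest, though its gap to compound 1 is within the scatter, as a 1.2-fold lower number from compound 1 to compound 3 (0.06 log units; within the scatter) shows; only compound 2 sits clearly apart, by a 5.0-fold lower number from compound 2 to compound 3 (0.70 log units; beyond the scatter).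

Compound 4 `N#C/C=C/c1ccc(C(NN)c2ccnc(Nc3ccc(C#N)cc3)n2)cc1` has not yet been measured. It differs from compound 3 in one place: amino in place of isopropyl on an amine nitrogen.

Among the measured compounds shown here, two measured steps bear on this change. The replacement of hydroxy by isopropyl on the same nitrogen gave a 5.0-fold lower number from compound 2 to compound 3 (0.70 log units; beyond the scatter), and the replacement of ethyl by hydroxy gave a 4.3-fold higher number from compound 1 to compound 2 (0.64 log units; beyond the scatter). The amino group entering in compound 4, like hydroxy, carries a hydrogen-bond donor and acceptor, whereas ethyl and isopropyl carry none and behaved alike. A higher number in this assay is therefore expected for compound 4, of modest size, close to a 3.7-fold higher number from compound 3 to compound 4 (0.57 log units; beyond the scatter). Compound 4 is estimated at 120000 nM, within 40000 nM to 300000 nM.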

Compound 4, half-maximal cytotoxic concentration: 186000 nM
Compound 4: the middle estimate sits 1.6-fold (0.19 log units) below what was measured, and the stated range covers the measured number.
By their numbers in this assay, from the lowest: compounds 3 and 1 (each within the scatter of the next); then compounds 2 and 4 (each within the scatter of the next).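

In this assay, amino and hydroxy on this amine nitrogen cannot be told apart, as a 1.2-fold higher number from compound 2 to compound 4 (0.06 log units; within the scatter) shows. Amino in place of the alkyl groups gives a step of modest size in both cases, with a 5.8-fold higher number from compound 3 to compound 4 (0.76 log units; beyond the scatter) for isopropyl and a 5.0-fold higher number from compound 1 to compound 4 (0.70 log units; beyond the scatter) for ethyl. Where a single step from hydroxy had set the earlier compounds apart, a second group now joins it, so the four compounds form two pairs, ethyl with isopropyl and hydroxy with amino, and none of them goes against this.

No measurement shown here accounts for the separation of the two pairs. From the compounds shown here alone, it stays open whether a methoxy group on this nitrogen would read with hydroxy and amino, and whether a longer chain such as butyl would read with ethyl and isopropyl.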